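Ring-nitrogen substituent swap: compound 2 to compound 3

The source may report more compounds than this note shows. Statements on the series, on what has been measured and on what is new or still open speak of the compounds shown alone.

compound 1 `O=C(CN1CCN(Cc2cccs2)CC1)C(O)(c1ccccc1)C1CCC1`: 43.8 nM in a functional assay on ileum for antagonist activity at muscarinic acetylcholine receptor M3 (Cavia porcellus); a lower number here means a stronger inhibitor, a higher number a weaker inhibitor
compound 2 `CCOc1ccccc1N1CCN(CC(=O)C(O)(c2ccccc2)C2CCC2)CC1`: a limit only, > 10000 nM in this assay

Compound 2 sits at the limit of > 10000 nM in this assay, at which 1 of the 2 values shown sits, so its value is a limit and not a number. Among the measured compounds shown here, the single measured step, an at least 220-fold higher number from compound 1 to compound 2 (2.35 log units; beyond the scatter), is large and goes toward weaker inhibition. Compound 3 `O=C(CN1CCN(CC(=O)C(O)(c2ccccc2)C2CCC2)CC1)N1CCCC1` carries ((pyrrolidin-1-yl)carbonyl)methyl in place of 2-ethoxyphenyl on an amine nitrogen in a ring; the group removed is the one that entered in an at least 220-fold higher number from compound 1 to compound 2 (2.35 log units; beyond the scatter). A move back toward lower numbers in this assay is therefore expected, estimated as an at least 33-fold lower number from compound 2 to compound 3 (1.52 log units; beyond the scatter), its size uncertain since it starts from a limit. Compound 3 is expected near 300 nM, within 50 nM to 3000 nM.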

Compound 3, antagonist equilibrium constant: 210 nM
Compound 3: middle estimate off by 1.4-fold (0.15 log units), on the high side, and the stated range covers the measured number.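

In this assay, the loss seen with 2-ethoxyphenyl is not shared by every group on this amine nitrogen, as ((pyrrolidin-1-yl)carbonyl)methyl gives an at least 47-fold lower number from compound 2 to compound 3 (1.67 log units; beyond the scatter). The (thiophen-2-yl)methyl of compound 1 still reads lower, with a 4.8-fold higher number from compound 1 to compound 3 (0.68 log units; beyond the scatter), so a group without a thiophene ring keeps a modest gap to it. Compound 2 is a limit and not a number, so the first step is only a bound: the limit of > 10000 nM in this assay, at which 1 of the 3 values shown sits.

Open, on these data alone, is whether a plain benzyl group here would read nearer compound 1 or compound 3. Also open, as far as these compounds go, is whether an open-chain diethylamide would match the pyrrolidine amide of compound 3.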